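Working notes: ethyl to methyl on the shared core

This account rests on a few compounds, and the source may have more. Where it says the series, first, only, none or still open, it means among the compounds named here.

In a physicochemical assay for solubility (on this read-out lower numbers stand for lower solubility and higher numbers for higher solubility), compound 1 `CS(=O)(=O)N(CCCO)c1c(Cl)c(Cl)cc2[nH]c(=O)c(=O)[nH]c12` reads 76 ug/mL and compound 3 `CC(O)CN(c1c(Cl)c(Cl)cc2[nH]c(=O)c(=O)[nH]c12)S(C)(=O)=O` reads 76 ug/mL on the same scale. Compound 2 `CCc1c(Cl)cc2[nH]c(=O)c(=O)[nH]c2c1N(CCO)S(C)(=O)=O` reads 72 ug/mL and lies within the scatter of both. Compound 4 `Cc1c(Cl)cc2[nH]c(=O)c(=O)[nH]c2c1N(CCO)S(C)(=O)=O` is still unmeasured and departs from compound 2 through hydrogen in place of methyl on a saturated chain carbon bound to an aromatic carbon with hydrogen in place of methyl on a saturated chain carbon bound to an aromatic carbon, so ethyl to methyl. Going by the values given here, the one measured step shows no change at the digits printed from compound 1 to compound 3 (within the scatter) for 1-hydroxyethyl in place of 2-hydroxyethyl on a saturated chain carbon bound to a sulfonamide nitrogen. Among the compounds with values here, no measured step touches the ethyl group, so the guidance is indirect. In this assay no step beyond the scatter is expected, with compound 2 at 72 ug/mL as the anchor. The estimated change is no change at the digits printed from compound 2 to compound 4 (within the scatter) and stays inside the scatter. Compound 4 is expected at 72 ug/mL with an estimated range from 40 ug/mL to 130 ug/mL for a single reading.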

Compound 4, solubility: 70 ug/mL
Estimate against measurement, compound 4: 1.0-fold (0.01 log units) above; the measured number falls inside the stated range.
By their numbers in this assay, from the lowest: compounds 4, 2, 1 and 3 (each within the scatter of the next).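

In this assay the change from ethyl to methyl, hydrogen in place of methyl on a saturated chain carbon bound to an aromatic carbon, gives a 1.0-fold lower number from compound 2 to compound 4 (0.01 log units; within the scatter) as the first step read at this position. The earlier step concerned only the chain on the sulfonamide nitrogen. No supporting data bear on this result.

As far as these compounds go, whether a longer chain such as propyl, an amine or a carboxylic acid on this carbon would also stay within the scatter remains open. So does whether this step would read the same with another chain on the sulfonamide nitrogen.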